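Methoxy Added to the Phenyl of Compound 1

The compounds below may be only part of what the source reports. "The series", "measured", "known", "first", "only" and "open" are said of these compounds alone.

Compound 1 `O[C@@H](c1ccccc1)[C@H]1CO[C@H](c2ccccc2)[C@@H](C/C=C/c2ccccc2)C1` is assessed in a functional assay on HL-60 cells (Homo sapiens) for cytotoxicity, read by WST assay, with a stated time of 48 h (on this read-out lower numbers stand for stronger inhibition and higher numbers for weaker inhibition), where compound 1 gives 7040 nM. Among three measured compounds it sits at one end of the numbers, yet within the scatter of both others. Compound 2 `Oc1ccccc1/C=C/C[C@H]1C[C@@H]([C@@H](O)c2ccccc2)CO[C@@H]1c1ccccc1` gives 10800 nM, and compound 3 `Oc1ccc(/C=C/C[C@H]2C[C@@H]([C@@H](O)c3ccccc3)CO[C@@H]2c2ccccc2)cc1` gives 7380 nM. Compound 4 `COc1cccc(/C=C/C[C@H]2C[C@@H]([C@@H](O)c3ccccc3)CO[C@@H]2c2ccccc2)c1` differs from compound 1 as follows: methoxy in place of hydrogen on an aromatic carbon. Going by the values given here, the steps that bear on this are a 1.5-fold higher number from compound 1 to compound 2 (0.19 log units; within the scatter) and a 1.0-fold higher number from compound 1 to compound 3 (0.02 log units; within the scatter), each a small group added on the same aromatic ring with no movement beyond the scatter. A similar outcome is therefore expected for compound 4, that is a 1.1-fold higher number from compound 1 to compound 4 (0.03 log units; within the scatter). Compound 4 is estimated at 7500 nM, with a range from 3500 nM to 16000 nM.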

Compound 4, half-maximal inhibitory concentration: 9620 nM
Compound 4: the middle estimate sits 1.3-fold (0.11 log units) below what was measured, within the range that was stated.
By their numbers in this assay, from the lowest: compounds 1, 3, 4 and 2 (each within the scatter of the next).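

In this assay, methoxy on this aromatic ring gives a 1.4-fold higher number from compound 1 to compound 4 (0.14 log units; within the scatter) and so, like hydroxy, stays within the scatter of compound 1. Comparing methoxy with either hydroxy compound also stays within the scatter, with a 1.3-fold higher number from compound 3 to compound 4 (0.12 log units; within the scatter) and a 1.1-fold lower number from compound 2 to compound 4 (0.05 log units; within the scatter) as the two steps. Nothing available explains why these numbers lie so close together.

Still open, as far as these compounds go, is whether an amine or a carboxylic acid on this ring would move the number beyond the scatter. From the compounds shown here alone, a longer chain in place of methoxy remains equally open.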